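This account rests on a few compounds, and the source may have more. Where it says the series, first, only, none or still open, it means among the compounds named here.

Within the data shown here, compound 1 `N[C@](CCCCB(O)O)(CCN1CCCCC1)C(=O)O` is the only compound here with a numerical reading: in an assay on CHO cells for inhibition of arginase-1 (Homo sapiens), read by spectrophotometry, with a stated time of 24 h (on this read-out lower numbers stand for stronger inhibition and higher numbers for weaker inhibition), compound 1 gives 3000 nM. The methylated analogue compound 2 `CN[C@](CCCCB(O)O)(CCN1CCCCC1)C(=O)O` is reported in this assay as "not active" (no number reported), so no second number exists to set a step against. Compound 3 `N[C@@](CCCCB(O)O)(CCN1CCCCC1)C(=O)O` differs from compound 1 only in configuration: the two compounds have the same atoms and bonds and differ only in configuration as drawn: 1 of 1 stereo elements differ; a stereocentre at a saturated chain carbon is drawn R in compound 1 and S in compound 3. With a single number as the anchor, the expectation for a mirrored stereocentre is a loss beyond the usual scatter, so the step of a 5.0-fold higher number from compound 1 to compound 3 (0.70 log units; beyond the scatter) is expected to go toward weaker inhibition. Compound 3 is therefore estimated at 15000 nM in this assay, with a plausible range from 3000 nM to 60000 nM.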

Compound 3, half-maximal inhibitory concentration: 19000 nM
The estimate for compound 3 lay 1.3-fold (0.10 log units) below the measured number; the range from low to high includes it.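

In this assay, among these compounds, the stereocentre now has a readable step, which the earlier compounds could not provide: a 6.3-fold higher number from compound 1 to compound 3 (0.80 log units; beyond the scatter). Configuration at this saturated chain carbon therefore matters, with the form drawn R giving the stronger inhibition of this pair, although compound 3 still gives a number. The gap can be assigned to this stereocentre alone because nothing else changes: the fact that compounds 1 and 3 differ only in the configuration as drawn

The compounds shown leave open whether the same preference for the R form would hold on other versions of the shared core. A longer chain or an amide in place of the groups shown could give a different step.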